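Cyclohexyl for butyl: expected step in the series

The source may hold more compounds than are shown below. What is called first, only, known or untested is meant among the compounds shown, and "the series" means these compounds.

compound 1 `O=C(/C=C/c1ccc([N+](=O)[O-])o1)c1ccc(C2CCCCC2)cc1`: 5100 nM
compound 2 `CC(C)(C)c1ccc(C(=O)/C=C/c2ccco2)cc1`: 18500 nM
compound 3 `CCCCc1ccc(C(=O)/C=C/c2ccco2)cc1`: 8400 nM

In a functional assay on C6 cells (Rattus norvegicus) for inhibition, read by sulforhodamine B assay, with a stated time of 72 h (a higher number here means that more compound is needed for the effect, a lower number that less compound is needed), the value of compound 1 and that of compound 3 lie within the scatter of each other. For the measured compounds named here, the only measured step that shows how compound 3 relates to another compound through a single change is a 2.2-fold lower number from compound 2 to compound 3 (0.34 log units; beyond the scatter), and it is modest. That step swaps one group for another on an aromatic carbon.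

The next compound, compound 4 `O=C(/C=C/c1ccco1)c1ccc(C2CCCCC2)cc1`, changes the group at that kind of place again: cyclohexyl in place of butyl on an aromatic carbon. The step from tert-butyl to butyl bears on this only loosely, since neither of its groups contains a ring. Going by the values given here, compound 1 already carries cyclohexyl and gives 5100 nM, but its core differs from that of compound 4, and no measured step isolates that difference. Among the compounds with values here, with only this evidence, no step beyond the scatter is expected in this assay, and no firm direction can be given. The estimated step is a 1.1-fold lower number from compound 3 to compound 4 (0.05 log units; within the scatter). For compound 4 the estimate is 7500 nM, with an expected range of 3500 nM to 16000 nM.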

Compound 4, half-maximal effective concentration: > 50000 nM
Compound 4: a limit, no number; the forecaster's own chance of this, stated with the estimate: 3%; middle value at least 6.6-fold (0.82 log units) away from the limit.
By their numbers in this assay, from the lowest: compounds 1 and 3 (each within the scatter of the next); then compound 2. At a limit, above all of these: compound 4.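

In this assay compound 4 is a limit and not a number: the limit of > 50000 nM in this assay, at which 1 of the 4 values shown sits. On this aromatic carbon the group is not interchangeable among alkyl substituents, as the earlier step alone might suggest: cyclohexyl gives an at least 5.9-fold higher number from compound 3 to compound 4 (0.77 log units; beyond the scatter) and an at least 2.7-fold higher number from compound 2 to compound 4 (0.43 log units; beyond the scatter), both beyond the scatter and both opposite in kind to the modest shift of a 2.2-fold lower number from compound 2 to compound 3 (0.34 log units; beyond the scatter). Cyclohexyl at this place does not by itself rule out a measurable value, since the pair that differs only at the nitro shows an at least 9.8-fold higher number from compound 1 to compound 4 (0.99 log units; beyond the scatter), so the outcome with cyclohexyl depends on whether nitro is present on the other side of the molecule.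

The compounds shown cannot separate the ring of cyclohexyl from its carbon count, a question that a hexyl chain or a cyclopentyl group at the same place would address. Going by these compounds, whether nitro shifts the number in the same way alongside butyl or tert-butyl also stays open, as does whether an amine or a carboxylic acid in place of that nitro would behave like it.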